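Methylating the phenol of compound 3: a reversal expected

The compounds below may be only part of what the source reports. "The series", "measured", "known", "first", "only" and "open" are said of these compounds alone.

The shared core is set out in compound 1 `COc1cc(C)c(Br)c(O)c1C(=O)c1c(C=O)c(O)cc(O)c1CC=C(C)C`, compound 2 `CC(C)=CCc1c(O)cc(O)c(C=O)c1C(=O)c1c(O)cc(C)c(Br)c1O` and compound 3 `CC(C)=CCc1c(O)cc(O)c(C=O)c1C(=O)c1c(O)cc(C)c(Cl)c1O`. In a functional assay on PANC-1 cells (Homo sapiens) for antiproliferative activity, read by MTT assay, with a stated time of 72 h (on this read-out higher numbers stand for weaker inhibition and lower numbers for stronger inhibition), compound 1 gives 26000 nM, compound 2 gives 7600 nM and compound 3 gives 7200 nM. Compound 3 carries the lowest number of the three, but its gap to compound 2 lies within the scatter, so those two cannot be ordered, while compound 1 sits well apart from both. Compound 4 `COc1cc(C)c(Cl)c(O)c1C(=O)c1c(C=O)c(O)cc(O)c1CC=C(C)C` differs from compound 3 by methyl in place of hydrogen on an oxygen on an aromatic ring. Among the measured compounds shown here, the one measured step that bears on this change runs in the opposite direction: a 3.4-fold lower number from compound 1 to compound 2 (0.53 log units; beyond the scatter). The swap of halogen, a 1.1-fold lower number from compound 2 to compound 3 (0.02 log units; within the scatter), left the number where it was. On that single precedent the added methyl is expected to undo the earlier gain, and compound 4 is expected to give 24000 nM, within the range 10000 nM to 50000 nM. This corresponds to an expected step of a 3.3-fold higher number from compound 3 to compound 4 (0.52 log units; beyond the scatter). For the measured compounds named here, with only one pair behind it, the estimate rests on a single observation.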

Compound 4, half-maximal inhibitory concentration: 14000 nM
Estimate against measurement, compound 4: 1.7-fold (0.23 log units) above; low and high end bracket the measured number.
By their numbers in this assay, from the lowest: compounds 3, 2, 4 and 1 (each within the scatter of the next, the first and the last beyond it).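

In this assay, the change from hydroxy to methoxy on the chloro compounds gives a 1.9-fold higher number from compound 3 to compound 4 (0.29 log units; within the scatter), so this step stays within the scatter, whereas the matching step on the bromo compounds lay beyond it. Even so, the two readings of this change cannot be told apart: the same change on two cores in this assay, a 3.4-fold lower number (0.53 log units; beyond the scatter) from compound 1 to compound 2 and a 1.9-fold lower number (0.29 log units; within the scatter) from compound 4 to compound 3, 1.8-fold (0.25 log units) apart, within the scatter of two such steps. The swap of halogen also stays within the scatter when the methoxy group is present, with a 1.9-fold lower number from compound 1 to compound 4 (0.27 log units; within the scatter), and it reads alike with hydroxy and with methoxy at this oxygen: the same change on two cores in this assay, a 1.1-fold lower number (0.02 log units; within the scatter) from compound 2 to compound 3 and a 1.9-fold lower number (0.27 log units; within the scatter) from compound 1 to compound 4, 1.8-fold (0.25 log units) apart, within the scatter of two such steps.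

The compounds shown leave open how a longer chain on this oxygen, or an amine in place of the hydroxy, would read in this assay. They also leave open whether fluoro on the same aromatic carbon would stay as close to chloro and bromo.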